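Urea series, one aryl swap on the ring nitrogen

The source may report more compounds than this note shows. Statements on the series, on what has been measured and on what is new or still open speak of the compounds shown alone.

Measured so far:
Compound 1, `Cc1ccc(Nc2cc(NC(=O)Nc3c(Cl)cccc3Cl)ncn2)cc1F`: in a functional assay on PC-9 cells (Homo sapiens) for inhibition, read by MTT assay, with a stated time of 48 h, tested at 10 uM (a lower number here means less inhibition, a higher number more inhibition at the concentration tested (going by the name of the read-out)), compound 1 gives 92%.
Compound 2, `COc1cc(NC(=O)Nc2cc(Nc3ccc(F)c(Cl)c3)ncn2)cc(OC)c1`: compound 2 gives 77.5%.
Compound 3, `COc1cc(NC(=O)Nc2cc(Nc3cc(I)ccc3OC)ncn2)cc(OC)c1`: compound 3 gives 91%.

Compound 1 holds the highest of the three numbers; compound 3 sits within the scatter of it, compound 2 beyond. Compound 4, `CCc1ccc(Nc2cc(NC(=O)Nc3c(Cl)cccc3Cl)ncn2)cc1`, is not yet measured. The change is 4-ethylphenyl in place of 3-fluoro-4-methylphenyl on a nitrogen on an aromatic ring. Among the measured compounds shown here, the one measured step at the same position, a number 13.5 percentage points higher from compound 2 to compound 3 (beyond the scatter), swapped a different pair of aryl groups, so it bears only loosely on this case; with compound 1 already near the top of the scale, little room remains upward. A step of no more than the scatter is expected, a number 7 percentage points lower from compound 1 to compound 4 (within the scatter). Compound 4 is estimated at 85%, within 70% to 95%.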

Compound 4, a percentage reported as inhibition, at one concentration (the size of the read-out at that concentration, not a potency): 70.1%
The estimate for compound 4 lay 14.9 percentage points above the measured number; low and high end bracket the measured number.
By their numbers in this assay, from the lowest: compounds 4 and 2 (each within the scatter of the next); then compounds 3 and 1 (each within the scatter of the next).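

In this assay, 4-ethylphenyl in place of 3-fluoro-4-methylphenyl gives a number 21.9 percentage points lower from compound 1 to compound 4 (beyond the scatter). The position on the aromatic ring nitrogen therefore responds to a change within a single aryl group, even with the same heavy-atom count on both sides, and with the 2,6-dichlorophenyl urea held constant, the step runs downward. No supporting data bear on the reason for this fall.

Which part of the change carries the fall, the loss of fluorine or ethyl in place of methyl, remains open. So does the outcome with a longer chain or an amine on that aryl ring.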